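A second chloro on the aryl ring of compound 1

A few compounds are considered here, and "the series" means these few. Any claim that something is new, unique, unknown or untested is made for them only; others in the source may bear on it.

Among the compounds with values here, compound 1 `O=C(O)C1CCN(c2ccccc2Cl)C1` carries a single chloro on its six-membered aromatic ring; in an assay on cells for inhibition of Palmitoleoyl-protein carboxylesterase NOTUM variant C330S (Homo sapiens), read by fluorescence, with a stated time of 40 min (on this read-out higher numbers stand for weaker inhibition and lower numbers for stronger inhibition), compound 1 gives 19000 nM, the highest of the three numbers so far. Compound 2 `Cc1cc(C(=O)O)c(C)n1-c1cccc(Cl)c1` is built on a different core, and the difference between the two cores is not broken down here; in this assay compound 2 gives 430 nM. Compound 3 `Cc1cc(C(=O)O)c(C)n1-c1cc(Cl)cc(Cl)c1` adds a chloro to compound 2 (chloro in place of hydrogen on an aromatic carbon); in this assay compound 3 gives 850 nM, a step of a 2.0-fold higher number from compound 2 to compound 3 (0.30 log units; within the scatter).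

Compound 4 `O=C(O)C1CCN(c2cccc(Cl)c2Cl)C1` applies the same kind of change to compound 1 (chloro in place of hydrogen on an aromatic carbon). The surroundings differ: in compound 3 the new chloro stands meta to a chloro group and meta to a large group, whereas in compound 4 it stands ortho to a chloro group and meta to a group of 8 heavy atoms, so the two changes are of the same kind, not the same. Nothing here separates the effect of the chloro from the effect of the core. The expected step from compound 1 to compound 4 is a 1.7-fold higher number from compound 1 to compound 4 (0.23 log units; within the scatter), taken from the step from compound 2 to compound 3 of a 2.0-fold higher number from compound 2 to compound 3 (0.30 log units; within the scatter). For compound 4 the estimate in this assay is 32000 nM, between 12000 nM and 85000 nM.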

Compound 4, half-maximal inhibitory concentration: 8000 nM
Compound 4: middle estimate off by 4.0-fold (0.60 log units), on the high side, and the stated range ends above it.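

In this assay the added chloro gives a 2.4-fold lower number from compound 1 to compound 4 (0.38 log units; beyond the scatter), so on the core of compound 1 the change goes with stronger inhibition, while on the core of compound 2 the step stays within the scatter. Set side by side, the two steps differ, so this change does not carry over from one core to the other as a fixed amount: the same change on two cores in this assay, a 2.0-fold higher number (0.30 log units; within the scatter) from compound 2 to compound 3 and a 2.4-fold lower number (0.38 log units; beyond the scatter) from compound 1 to compound 4, 4.7-fold (0.67 log units) apart, beyond the scatter of two such steps

This does not show what drives the difference: the new chloro also sits differently in the two pairs, ortho to a chloro group only in compound 4, so core and placement are not separated, and two pairs give no rule for the series.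

Open, as far as these compounds go, is whether a chloro placed ortho to a chloro group on the core of compound 2 would follow the step on the core of compound 1 or the step from compound 2 to compound 3. Also open, from the compounds shown here alone, is whether a fluoro or a methoxy group on the same aromatic carbon of compound 1 would go the same way as the chloro.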